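The compounds below may be only part of what the source reports. "The series", "measured", "known", "first", "only" and "open" are said of these compounds alone.

Three compounds share one core and differ only in the chain hanging from an oxygen on an aromatic ring. In a functional assay (Homo sapiens) for antiproliferative activity, read by resazurin assay, with a stated time of 48 h, tested at 5 uM (on this read-out lower numbers stand for a weaker effect and higher numbers for a stronger effect at the one concentration tested), compound 1 `COc1cc(OC)c2c(=O)cc(-c3ccc(OCCCN(C)C)cc3)oc2c1` gives 36%, compound 2 `COc1cc(OC)c2c(=O)cc(-c3ccc(OCCN)cc3)oc2c1` gives 6%, and compound 3 `COc1cc(OC)c2c(=O)cc(-c3ccc(OCCCN)cc3)oc2c1` gives 22%. Compound 3 therefore stands second of the three, with compound 1 above it and compound 2 below it.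

The steps between these three all point the same way: a number 30 percentage points lower from compound 1 to compound 2 (beyond the scatter), a number 14 percentage points lower from compound 1 to compound 3 (beyond the scatter) and a number 16 percentage points higher from compound 2 to compound 3 (beyond the scatter). A longer chain and a dimethylamino in place of a plain amino each went with a higher number.

Compound 4 `COc1cc(OC)c2c(=O)cc(-c3ccc(OCC(O)CN4CCCC4)cc3)oc2c1` has not been measured. Its change from compound 3 is 1-hydroxy-2-(pyrrolidin-1-yl)ethyl in place of 2-aminoethyl on a saturated chain carbon bound to an oxygen on an aromatic ring. For the measured compounds named here, the entering group lengthens the chain again and, like the dimethylamino of compound 1, carries a nitrogen inside a pyrrolidin-1-yl rather than a bare amino; a hydroxy is added as well, for which no measured step exists. The steps from compound 2 and compound 3 toward compound 1 suggest an expected rise, though the added hydroxy is an unknown, so the expected step is a number 12 percentage points higher from compound 3 to compound 4 (beyond the scatter). Compound 4 is thus estimated at 34% in this assay, within a range from 15% to 55%.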

Compound 4, a percentage reported as inhibition, at one concentration (the size of the read-out at that concentration, not a potency): 21%
For compound 4 the middle estimate is 13 percentage points above the measured one, and the stated range covers the measured number.
By their numbers in this assay, from the lowest: compound 2; then compounds 4 and 3 (each within the scatter of the next); then compound 1.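

In this assay the step to the larger chain is a number 1 percentage points lower from compound 3 to compound 4 (within the scatter) even though a group of 8 heavy atoms, with a five-membered ring and a hydroxy, replaces one of 3 heavy atoms, so this position takes the 2-hydroxy-3-(pyrrolidin-1-yl)propoxy chain with no readable change from the 3-aminopropoxy chain. The other two steps are a number 15 percentage points higher from compound 2 to compound 4 (beyond the scatter) and a number 15 percentage points lower from compound 1 to compound 4 (beyond the scatter) and they place the new chain clearly above the shortest chain but clearly below the dimethylamino chain, so compound 4 goes against the earlier trend in which a longer chain and a substituted nitrogen each went with a higher number. Nothing available explains this result.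

The compounds shown leave open how much of this outcome belongs to the hydroxy and how much to the pyrrolidine ring, since the two enter together. A 3-(pyrrolidin-1-yl)propoxy chain without the hydroxy, or a 2-hydroxy-3-(dimethylamino)propoxy chain, would pull those two changes apart.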